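Swapping Ethylamino for Fluoro in Compound 4

The source may hold more compounds than are shown below. What is called first, only, known or untested is meant among the compounds shown, and "the series" means these compounds.

The three measured compounds share one core and differ only at a single aromatic carbon. In a functional assay on the whole organism with Rattus norvegicus as the target (on this read-out lower numbers stand for an effect already at smaller amounts and higher numbers for an effect only at larger amounts of compound), compound 1 `CCOC(=O)C(=O)Nc1cccc(OC)c1C#N` gives 55.5 mg/kg, compound 2 `CCNc1cccc(NC(=O)C(=O)OCC)c1C#N` gives 0.03 mg/kg, and compound 3 `CCCNc1cccc(NC(=O)C(=O)OCC)c1C#N` gives 0.7 mg/kg. Compound 2 stands lowest of the three: the step of a 23-fold higher number from compound 2 to compound 3 (1.37 log units; beyond the scatter) separates it from its nearest neighbour, and the step of a 1900-fold lower number from compound 1 to compound 2 (3.27 log units; beyond the scatter) from the furthest.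

Compound 4 `CCOC(=O)C(=O)Nc1cccc(F)c1C#N` is reached from compound 2 by the change (fluoro in place of ethylamino on an aromatic carbon). Among the compounds with values here, the steps that bear on it are those in which the ethylamino group is replaced: a 1900-fold lower number from compound 1 to compound 2 (3.27 log units; beyond the scatter) shows that methoxy in its place gives a far higher number, and a 79-fold lower number from compound 1 to compound 3 (1.90 log units; beyond the scatter) shows that even propylamino sits well above ethylamino. Fluoro carries no hydrogen-bond donor or acceptor, and no measured compound tells how such a group behaves here. For compound 4 a large step upward in this assay is nevertheless expected, of the order of a 2000-fold higher number from compound 2 to compound 4 (3.30 log units; beyond the scatter). The estimate for compound 4 in this assay is therefore 60 mg/kg, within a range from 10 mg/kg to 300 mg/kg. Whether compound 4 lands near compound 1 or beyond it cannot be settled from these three compounds alone.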

Compound 4, dose for half-maximal effect: 59 mg/kg
Beside the measured number, compound 4's estimate is 1.0-fold (0.01 log units) above it; measured number inside the range.
By their numbers in this assay, from the lowest: compound 2; then compound 3; then compounds 1 and 4 (each within the scatter of the next).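

Read in this assay the change to fluoro brings a 2000-fold higher number from compound 2 to compound 4 (3.29 log units; beyond the scatter) and, starting from the propylamino group, an 84-fold higher number from compound 3 to compound 4 (1.93 log units; beyond the scatter) so the low numbers seen with ethylamino and propylamino are not kept at this aromatic carbon. The earlier compounds shown here offered only methoxy as a group without a nitrogen at this place, and a 1.1-fold higher number from compound 1 to compound 4 (0.03 log units; within the scatter) now shows that fluoro and methoxy cannot be told apart in this assay although they are different groups. Across these four compounds, then, the low numbers belong only to the two compounds with an alkylamino group, none of the four goes against this, and the ethylamino compound stays well below the propylamino one.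

It remains open whether the nitrogen alone carries this effect, since the compounds shown do not reveal how a plain amino group, methylamino, dimethylamino, a hydroxyl or a chloro group would behave at this carbon. No measurement shown here explains why fluoro and methoxy differ so far from the alkylamino groups.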